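This account rests on a few compounds, and the source may have more. Where it says the series, first, only, none or still open, it means among the compounds named here.

In a toxicity assay on THP-1 cells (Homo sapiens) for inhibition (on this read-out higher numbers stand for lower toxicity in this test and lower numbers for higher toxicity in this test), the series offers limits only. Compound 1 (`COc1ccc(-c2cnc(NC(=O)c3ccccc3O)n2C)cc1`) reads > 100000 nM as a limit. Compound 2 (`COc1ccc(-c2cnc(NC(=O)C3CCNCC3)n2C)cc1`) reads > 100000 nM as a limit too. Compound 3 (`COc1ccc(-c2cnc(NC(=O)c3ccco3)n2C)cc1`) reads > 100000 nM as a limit as well, and no number is known for it. Its position is therefore the limit of > 100000 nM in this assay, at which 3 of the 3 values shown sit, and nothing finer.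

Compound 4 (`COc1ccc(-c2cnc(NC(=O)c3ccno3)n2C)cc1`) differs from compound 3 by one change (1,2-oxazol-5-yl in place of furan-2-yl on a carbonyl carbon), with 1,2-oxazol-5-yl in place of furan-2-yl on a carbonyl carbon. Three measured steps at that same place bear on it, namely a step that the two limits leave unreadable from compound 1 to compound 2 and a step that the two limits leave unreadable from compound 1 to compound 3 and a step that the two limits leave unreadable from compound 2 to compound 3 and none of them has a readable size. Each of those exchanges ended at the limit, so no step beyond the scatter and no direction is expected in this assay for this change. The expected step is a number no higher from compound 3 to compound 4 (the limit leaves the size open) on this estimate. Compound 4 is estimated at 100000 nM with an expected range from 50000 nM to 200000 nM and is likely to be reported as a limit again.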

Compound 4, half-maximal cytotoxic concentration: > 100000 nM
Compound 4 ended at the assay's limit; the forecaster's own chance of this, stated with the estimate: 90%; the middle value lies on the limit itself.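

No new step can be read: compound 4 sits at the assay's limit, as do compound 1, compound 2 and compound 3, in this assay: the limit of > 100000 nM in this assay, at which 4 of the 4 values shown sit.

The compounds shown leave open whether any group on the carbonyl carbon changes the reading in this assay at all.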